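The source may report more compounds than this note shows. Statements on the series, on what has been measured and on what is new or still open speak of the compounds shown alone.

Two compounds in this series carry measurements so far. Compound 1 `Cc1ccc(C(=O)CSc2nc3ccccc3[nH]2)cc1` in a functional assay on HT-29 cells (Homo sapiens) for inhibition, read by WST assay, with a stated time of 48 h (a higher number here means a weaker inhibitor, a lower number a stronger inhibitor), gives 34500 nM. Compound 2 `COc1ccc(C(=O)CSc2nc3ccccc3[nH]2)cc1O` in this assay gives 33100 nM, the lower of the two numbers, although its gap to compound 1 lies within the usual scatter, so no order between the two can be read. Compound 3 `COc1ccc(C(=O)CSc2nc3ccccc3[nH]2)cc1` is not yet measured. It differs from compound 2 by hydrogen in place of hydroxy on an aromatic carbon. For the measured compounds named here, no step between measured compounds bears on this kind of change, so the expectation rests on the two values alone, which sit close together despite different substitution on the same ring. The step from compound 2 to compound 3 is expected to be small, with no clear direction and probably within the scatter, a 1.1-fold higher number from compound 2 to compound 3 (0.02 log units; within the scatter). Compound 3 is accordingly estimated at 35000 nM, with a range from 15000 nM to 80000 nM.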

Compound 3, half-maximal inhibitory concentration: 25200 nM
The estimate for compound 3 lay 1.4-fold (0.14 log units) above the measured number, within the range that was stated.
By their numbers in this assay, from the lowest: compounds 3, 2 and 1 (each within the scatter of the next).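

In this assay hydrogen in place of hydroxy ortho to a methoxy group gives a 1.3-fold lower number from compound 2 to compound 3 (0.12 log units; within the scatter) and so shows no readable effect of the hydroxy at this position. Methoxy in place of methyl on an aromatic carbon gives a 1.4-fold lower number from compound 1 to compound 3 (0.14 log units; within the scatter) and likewise allows no order between those two compounds, so the three compounds remain unranked. No measured evidence bears on why these steps are small.

Still open, from the compounds shown here alone, is whether any replacement on this ring moves the number beyond the scatter, for example an amine or a carboxylic acid in place of the hydroxy. A longer chain such as ethoxy in place of the methoxy, or a nitrile in place of the methyl, is equally unresolved by the compounds shown.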